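The compounds below may be only part of what the source reports. "The series", "measured", "known", "first", "only" and "open" are said of these compounds alone.

Two compounds from this series carry a measurement. Compound 1 `COc1cc2c(cc1OC)C(CC(=O)O)CC2` gives 23.9% in a functional assay on the whole organism (strain Wistar) for inhibition, with Rattus norvegicus as the target, read by paw edema, with a stated time of 4 h, at a dose of 100 mg/kg; on this read-out higher numbers stand for more inhibition at the one dose given (going by the name of the read-out) and lower numbers for less inhibition. Compound 2 `COc1cc2c(cc1OC)C(CC(=O)Nc1ccccc1)CC2` gives 37.5% in the same assay, the higher of the two numbers, and the step of a number 13.6 percentage points higher from compound 1 to compound 2 (beyond the scatter) lies beyond the scatter. Compound 3 `COc1cc2c(cc1OC)C(CC(=O)Nc1cccc(Cl)c1)CC2` has not been measured. It differs from compound 2 by chloro in place of hydrogen on an aromatic carbon. For the measured compounds named here, no measured step bears directly on this change: the only step on record, from compound 1 to compound 2, concerns the amide end and not a substituent on the aromatic ring, so it offers no guide to the size or direction of the change to compound 3. With nothing to point either way, the account expects the step of a number 2.5 percentage points higher from compound 2 to compound 3 (within the scatter) to fall within the scatter. For compound 3 the estimated value in this assay is 40%, with a range from 25% to 55%.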

Compound 3, a percentage reported as inhibition, in the whole organism at one dose (the size of the read-out at that dose, not a potency): 25.8%
Beside the measured number, compound 3's estimate is 14.2 percentage points above it; measured number inside the range.
By their numbers in this assay, from the lowest: compounds 1 and 3 (each within the scatter of the next); then compound 2.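

The ring of the anilide is not indifferent in this assay: chloro in place of hydrogen, on an aromatic carbon meta to a large group, gives a number 11.7 percentage points lower from compound 2 to compound 3 (beyond the scatter), so this position bears on the read-out at the one dose given. The gain seen with the plain anilino group does not carry over to this substituted one, as a number 1.9 percentage points higher from compound 1 to compound 3 (within the scatter) leaves compound 3 within the scatter of the carboxylic acid. No measurement on hand accounts for this drop.

The compounds shown leave open whether the loss belongs to chloro itself or would also appear with a methoxy group or a fluoro at the same place. They also leave open whether chloro on another carbon of that ring would give the same result.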